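An Iodo Substituent on the Core of Compound 1

The source may report more compounds than this note shows. Statements on the series, on what has been measured and on what is new or still open speak of the compounds shown alone.

Compound 1, `Cc1cc(=O)[nH]c(=O)n1COC(CO)CO`: in a functional assay on NCI-H460 cells (Homo sapiens) for inhibition, read by MTT assay, with a stated time of 72 h (on this read-out higher numbers stand for weaker inhibition and lower numbers for stronger inhibition), compound 1 gives > 100000 nM, a limit of the assay and not a number.
Compound 2, `O=c1ccn(COC(CO)CO)c(=O)[nH]1`: in this assay compound 2 gives > 100000 nM, likewise a limit.
Compound 3, `O=C(CCl)Nc1cn(COC(CO)CO)c(=O)[nH]c1=O`: in this assay compound 3 gives 24000 nM.

Compound 1 stands only at a limit, and because it shares the limit of > 100000 nM in this assay, at which 2 of the 3 values shown sit, with compound 2, the step that the two limits leave unreadable from compound 1 to compound 2 cannot be read. Within the data shown here, the one readable step is an at least 4.1-fold lower number from compound 2 to compound 3 (0.61 log units; beyond the scatter), a substituent entering an aromatic carbon of the shared core.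

Compound 4, `Cc1c(I)c(=O)[nH]c(=O)n1COC(CO)CO`, differs from compound 1 by iodo in place of hydrogen on an aromatic carbon. Among the measured compounds shown here, no measured step introduces iodo, and the readable step concerns a different group, so it bears only loosely on this change. Compound 4 is therefore expected to remain near the limit, with an expected step of an at least 1.2-fold lower number from compound 1 to compound 4 (0.09 log units; that floor lies within the scatter). Compound 4 is estimated at 80000 nM, within 20000 nM to 300000 nM.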

Compound 4, half-maximal inhibitory concentration: > 100000 nM
Compound 4 gave a limit, no number; the forecaster's own chance of this, stated with the estimate: 55%; middle value at least 1.2-fold (0.09 log units) from the limit.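

Compound 4 gives > 100000 nM as a limit of the assay and not a number. Among these compounds, compound 1 also stands at a limit, so no step between compound 1 and compound 4 can be read: the limit of > 100000 nM in this assay, at which 3 of the 4 values shown sit.

In this assay the compounds shown leave open whether iodo in place of hydrogen changes the number at all.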